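The source may report more compounds than this note shows. Statements on the series, on what has been measured and on what is new or still open speak of the compounds shown alone.

Series of aziridine-nitrile ureas, tested in a functional assay on RPMI-8226 cells (Homo sapiens) for inhibition; a lower number here means a stronger inhibitor, a higher number a weaker inhibitor.

Compound 1 `CCCCNC(=O)N1CC1C#N` carries a butyl group on the urea nitrogen and gives 17000 nM in this assay. Compound 2 `N#CC1CN1C(=O)NC1CCCCC1` carries a cyclohexyl group instead and gives 98000 nM in this assay. Compound 3 `N#CC1CN1C(=O)Nc1ccc(S(N)(=O)=O)cc1` carries a sulfonamide-substituted phenyl group; its value in this assay is a limit, > 38000 nM, not a number. Within the numbers shown, compound 1 stands lowest; the gap to compound 2 lies beyond the usual scatter, so the butyl compound is the stronger of the two, while compound 3 gives only (the limit of > 38000 nM in this assay, at which 1 of the 3 values shown sits).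

Compound 4 `CNC(=O)N1CC1C#N` is the next member: hydrogen in place of propyl on a saturated chain carbon bound to an amide-type nitrogen, which shortens butyl to methyl. Among the compounds with values here, no two measured compounds differ in one place, so there is no measured step to lean on. Both larger replacements, cyclohexyl in compound 2 and the aryl in compound 3, sit higher than compound 1; cutting the chain back removes most of what distinguishes compound 1 from its neighbours, and a weaker value is expected, the step from compound 1 to compound 4 estimated at a 2.4-fold higher number from compound 1 to compound 4 (0.37 log units; beyond the scatter). Compound 4 is expected to give 40000 nM in this assay, with a range of 12000 nM to 140000 nM.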

Compound 4, half-maximal inhibitory concentration: 26000 nM
Beside the measured number, compound 4's estimate is 1.5-fold (0.19 log units) above it, and the stated range covers the measured number.
By their numbers in this assay, from the lowest: compounds 1 and 4 (each within the scatter of the next); then compound 2.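

In this assay, the change from butyl to methyl gives a 1.5-fold higher number from compound 1 to compound 4 (0.18 log units; within the scatter). Within the data shown here, this is the first one-place step, and it shows that, at this position on the urea nitrogen, cutting the chain back to methyl leaves the number within the scatter, so the propyl portion of the butyl group is not needed to keep the value in this range. Nothing in hand on measured properties bears on this step.

Going by these compounds, whether a hexyl chain, or a butyl chain ending in an amine or a carboxylic acid, would move the number beyond the scatter remains open. On these data alone, compound 3 gives > 38000 nM, which is a limit and not a number, so how the sulfonamide-substituted phenyl group compares in this assay also stays open.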